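A few compounds are considered here, and "the series" means these few. Any claim that something is new, unique, unknown or untested is made for them only; others in the source may bear on it.

Measured so far in a functional assay on H520 cells (Homo sapiens) for antiproliferative activity; on this read-out higher numbers stand for weaker inhibition and lower numbers for stronger inhibition:
compound 1 `O=C(CCCCC[C@H](NC(=O)c1ccc(Br)cc1)C(=O)Nc1ccc(-c2ccccc2)cc1)NO` gives 117 nM;
compound 2 `CN(C)c1ccc(C(=O)N[C@@H](CCCCCC(=O)NO)C(=O)Nc2cccc3cccnc23)cc1` gives 63 nM;
compound 3 `O=C(/C=C/c1ccccc1)N[C@@H](CCCCCC(=O)NO)C(=O)Nc1cccc2cccnc12` gives 27 nM.

Compound 3 stands lowest of the three, the step of a 2.3-fold lower number from compound 2 to compound 3 (0.37 log units; beyond the scatter) setting it apart from compound 2, with compound 1 higher still. Compound 4 `O=C(CCCCC[C@H](NC(=O)OCc1ccccc1)C(=O)Nc1cccc2cccnc12)NO` carries the change (benzyloxy in place of 2-phenylethenyl on a carbonyl carbon). Among the compounds with values here, only one measured step touches this carbonyl carbon, a 2.3-fold lower number from compound 2 to compound 3 (0.37 log units; beyond the scatter), and it was modest. Within the data shown here, no measured compound carries a benzyloxy group on this carbonyl, so the direction is uncertain, and the step of a 1.7-fold higher number from compound 3 to compound 4 (0.22 log units; within the scatter) is expected to be small, probably toward a slightly higher number. Compound 4 is estimated at 45 nM in this assay, within the range 18 nM to 120 nM.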

Compound 4, half-maximal inhibitory concentration: 118 nM
Compound 4: the middle estimate sits 2.6-fold (0.42 log units) below what was measured; measured number inside the range.
By their numbers in this assay, from the lowest: compound 3; then compounds 2, 1 and 4 (each within the scatter of the next).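

In this assay, benzyloxy in place of 2-phenylethenyl on this carbonyl carbon gives a 4.4-fold higher number from compound 3 to compound 4 (0.64 log units; beyond the scatter) and thus a second step beyond the scatter at this position. Benzyloxy in place of 4-(dimethylamino)phenyl gives a 1.9-fold higher number from compound 2 to compound 4 (0.27 log units; within the scatter), so these two groups are not separated here, while 2-phenylethenyl stands apart from both. Nothing measured here explains this difference. As far as these compounds go, it remains open whether a 2-phenylethyl group or a phenylamino group on this carbonyl carbon would read like compound 3 or like compound 4.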